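This account rests on a few compounds, and the source may have more. Where it says the series, first, only, none or still open, it means among the compounds named here.

Compound 1 `Cc1cc(-c2cccc(F)c2)c2ncc(CSCCc3ccccc3)n2c1`: in an ADME assay on HEL cells (Homo sapiens) for cytotoxicity, with a stated time of 3 days (a lower number here means that less compound is tolerated, a higher number that more compound is tolerated), compound 1 gives 35 ug/mL.
Compound 2 `COc1cccc(-c2cc(C)cn3c(CSCCc4ccccc4)cnc23)c1`: in this assay compound 2 reaches only the limit of the assay, > 50 ug/mL.
Compound 3 `Cc1cc(-c2cccs2)c2ncc(CSCCc3ccccc3)n2c1`: in this assay compound 3 likewise reaches only the limit, > 50 ug/mL.

Compound 3 therefore stands at the ceiling of the measurement, (the limit of > 50 ug/mL in this assay, at which 2 of the 3 values shown sit). Between compound 2 and compound 3 the two limits leave the step unreadable, a step that the two limits leave unreadable from compound 2 to compound 3. Compound 4 `COc1ccc(-c2cc(C)cn3c(CSCCc4ccccc4)cnc23)cc1` differs from compound 3 in one place: 4-methoxyphenyl in place of thiophen-2-yl on an aromatic carbon. For the measured compounds named here, two measured steps bear on this change. Replacing the fluorophenyl by the thiophene gave an at least 1.4-fold higher number from compound 1 to compound 3 (0.15 log units; that floor lies within the scatter), and putting methoxy in place of fluoro gave an at least 1.4-fold higher number from compound 1 to compound 2 (0.15 log units; that floor lies within the scatter); both are floors that lie within the scatter. Compound 2 already carries a methoxyphenyl and sits at the limit, > 50 ug/mL. Compound 4 is therefore expected to be tolerated to a similar degree, the step of a number no higher from compound 3 to compound 4 (the limit leaves the size open) being expected to stay within the scatter. The estimate for compound 4 in this assay is 50 ug/mL, between 25 ug/mL and 90 ug/mL.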

Compound 4, half-maximal cytotoxic concentration: 19.6 ug/mL
Estimate against measurement, compound 4: 2.6-fold (0.41 log units) above; measured number outside the range, below it.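

In this assay, this aromatic carbon does not treat all aryl groups alike: moving the methoxy group on the phenyl ring gives an at least 2.5-fold lower number from compound 2 to compound 4 (0.40 log units; beyond the scatter). Replacing thiophen-2-yl by 4-methoxyphenyl gives an at least 2.5-fold lower number from compound 3 to compound 4 (0.40 log units; beyond the scatter), whereas the change from 3-fluorophenyl gives a 1.8-fold lower number from compound 1 to compound 4 (0.25 log units; within the scatter), so compound 1 and compound 4 cannot be told apart. The two larger steps are floors, as each starts from a limit rather than a number: the limit of > 50 ug/mL in this assay, at which 2 of the 4 values shown sit.

The compounds shown leave open whether the lower number in this assay belongs to the methoxy group itself or would also appear with 4-chlorophenyl or 4-aminophenyl on this carbon. They also leave open how an aryl group carrying a carboxylic acid would read there.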